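The source may hold more compounds than are shown below. What is called first, only, known or untested is meant among the compounds shown, and "the series" means these compounds.

Measured in a functional assay on A549 cells (Homo sapiens) for inhibition, read by MTT assay, with a stated time of 24 h; on this read-out higher numbers stand for weaker inhibition and lower numbers for stronger inhibition:
- compound 1 `COc1ccccc1-n1cc(CN2C(=O)C[C@@H]3CC[C@@]2(C)C3(C)C)nn1` – 350 nM
- compound 2 `CC1(C)[C@H]2CC[C@]1(C)N(Cc1cn(-c3ccc(Cl)cc3)nn1)C(=O)C2` – 70 nM

Compound 2, at 70 nM, has the lower of the two numbers in this assay. The next compound, compound 3 `Cc1cccc(-n2cc(CN3C(=O)C[C@@H]4CC[C@@]3(C)C4(C)C)nn2)c1`, carries 3-methylphenyl in place of 4-chlorophenyl on an aromatic nitrogen. Going by the values given here, only one measured step bears on this change, a 5.0-fold lower number from compound 1 to compound 2 (0.70 log units; beyond the scatter), which alters the group on the same nitrogen. Among the compounds with values here, with only that modest step as a guide, a smaller move toward a higher number is expected in this assay. The estimated step is a 2.4-fold higher number from compound 2 to compound 3 (0.39 log units; beyond the scatter). For compound 3 the expected value is 170 nM, with an estimated range of 60 nM to 480 nM.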

Compound 3, half-maximal inhibitory concentration: 50 nM
Compound 3: the middle estimate sits 3.4-fold (0.53 log units) above what was measured; the measured number lies below the stated range.
By their numbers in this assay, from the lowest: compounds 3 and 2 (each within the scatter of the next); then compound 1.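

In this assay, exchanging 4-chlorophenyl for 3-methylphenyl on the aromatic nitrogen gives a 1.4-fold lower number from compound 2 to compound 3 (0.15 log units; within the scatter), so these two groups are not told apart here. Going by these compounds alone, replacing 2-methoxyphenyl with 3-methylphenyl gives a 7.0-fold lower number from compound 1 to compound 3 (0.85 log units; beyond the scatter), leaving compound 1 as the only compound separated from both others by steps beyond the scatter. No evidence is available to explain these results. Because compound 2 and compound 3 differ in both the substituent and its location on the phenyl ring, those two changes cannot be separated. Going by these compounds, how an amine or a carboxylic acid on that ring would read remains open.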